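Dithiocarbamate series: side-chain terminal group, resazurin cytotoxicity

A few compounds are considered here, and "the series" means these few. Any claim that something is new, unique, unknown or untested is made for them only; others in the source may bear on it.

Measured so far:
compound 1, `OCCCSC(=S)NCc1cccnc1`, 6610 nM in a functional assay on MDA-MB-468 cells (Homo sapiens) for cytotoxicity, read by resazurin assay, with a stated time of 72 h; a higher number here means a weaker inhibitor, a lower number a stronger inhibitor
compound 2, `NC(=O)CCSC(=S)NCc1cccnc1`, 4630 nM in this assay

The two measured compounds share the same core and differ only in the terminal group of the saturated chain. For the measured compounds named here, the one measured step, a 1.4-fold lower number from compound 1 to compound 2 (0.15 log units; within the scatter), is within the scatter, so compound 2 and compound 1 cannot be told apart on these numbers; compound 2 simply holds the lower of the two values.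

Compound 3, `O=S(=O)(O)CCCSC(=S)NCc1cccnc1`, carries the change (sulfomethyl in place of carbamoyl on a saturated chain carbon, two bonds along the chain from a sulfur). Going by the values given here, only the step from compound 1 to compound 2 bears on this change, as it alters the same terminal group at the same place, and it was within the scatter. Nothing in the series shows the terminal group moving the read-out beyond the scatter, so no step beyond the scatter is expected for compound 3, though the incoming group is a larger departure than the measured one, and the range is set wide. The step from compound 2 to compound 3 is estimated at a 1.4-fold higher number from compound 2 to compound 3 (0.15 log units; within the scatter). Compound 3 is therefore expected to give 6500 nM, within 2500 nM to 17000 nM.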

Compound 3, half-maximal inhibitory concentration: 11100 nM
The estimate for compound 3 lay 1.7-fold (0.23 log units) below the measured number; low and high end bracket the measured number.
By their numbers in this assay, from the lowest: compounds 2, 1 and 3 (each within the scatter of the next, the first and the last beyond it).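

In this assay, for the compounds shown here, the terminal group at this place now gives a step beyond the scatter for the first time: a 2.4-fold higher number from compound 2 to compound 3 (0.38 log units; beyond the scatter) is a modest step, with sulfomethyl in place of carbamoyl on a saturated chain carbon, two bonds along the chain from a sulfur. That separation depends on the comparison chosen, since sulfo in place of hydroxy on a saturated chain carbon, three bonds along the chain from a sulfur gives a 1.7-fold higher number from compound 1 to compound 3 (0.23 log units; within the scatter) and stays within the scatter, so compound 1 cannot be told apart from either of the other two. No measurement at hand bears on the reason for either step.

Still open, from the compounds shown here alone, is whether the sulfo group itself matters here or whether the gap simply reflects the carbamoyl end of compound 2, and a carboxylic acid or an amine at the end of the same chain would separate these readings. A longer chain carrying the sulfo group would show whether the read-out follows the terminal group or its distance from the sulfur.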